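A Dichloro Swap on a Long-Chain Urea

The compounds below may be only part of what the source reports. "The series", "measured", "known", "first", "only" and "open" are said of these compounds alone.

Of the compounds shown here, two have been measured in an assay on microsomes from intestinal mucosa for inhibition of acyl-CoA:cholesterol acyltransferase (Oryctolagus cuniculus); on this read-out higher numbers stand for weaker inhibition and lower numbers for stronger inhibition. Compound 1, `CCCCCCCCCCCCCCCCCCOc1c(C)cccc1C`, has a long saturated chain joined to its ring through an oxygen. Compound 1 reaches only a limit of the assay, > 10000 nM, so no number is known for it. Compound 2, `CCCCCCCC/C=C\CCCCCCCCNC(=O)Nc1c(C)cc(C)cc1C`, joins an unsaturated chain through a urea to a trimethyl-substituted ring. In this assay compound 2 gives 2900 nM. For the measured compounds named here, of the two results, that of compound 2 is the only actual number; the result of compound 1 is a limit, (the limit of > 10000 nM in this assay, at which 1 of the 2 values shown sits). Going by the values given here, no two measured compounds differ in a single place, so no measured step is available.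

Compound 3, `CCCCCCCC/C=C\CCCCCCCCNC(=O)Nc1c(Cl)cccc1Cl`, is the untested analogue. It differs from compound 2 in one way: 2,6-dichlorophenyl in place of 2,4,6-trimethylphenyl on an amide-type nitrogen. With only the two results above to go on, the step is expected to be modest, and the step from compound 2 to compound 3 is estimated as a 1.4-fold higher number from compound 2 to compound 3 (0.14 log units; within the scatter), close to the scatter. Compound 3 is therefore expected to give about 4000 nM, with a range from 1500 nM to 12000 nM.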

Compound 3, half-maximal inhibitory concentration: 400 nM
For compound 3 the middle estimate is 10-fold (1.00 log units) above the measured one; the measured number lies below the stated range.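

In this assay, the group on the amide-type nitrogen proves able to move the result: 2,6-dichlorophenyl in place of 2,4,6-trimethylphenyl gives a 7.3-fold lower number from compound 2 to compound 3 (0.86 log units; beyond the scatter), which here means stronger inhibition. For the compounds shown here, this is the first measured step. The long unsaturated chain and the urea stay the same in both compounds, so it can be tied to this one exchange of ring groups. The exchange removes the methyl groups and brings in chlorine atoms in a single move, and nothing measured here bears on why the number dropped.

On these data alone, it remains open whether the chlorine atoms, the missing third substituent on the ring, or both account for the step, which 2,6-dimethylphenyl or 2,4,6-trichlorophenyl on the same urea would help to separate. Also open, as far as these compounds go, is how far the trend extends to other ring groups, such as 2,6-difluorophenyl or 2,6-dibromophenyl, and whether it would hold with a shorter chain on the other side of the urea.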